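The compounds below may be only part of what the source reports. "The series", "measured", "known", "first", "only" and "open" are said of these compounds alone.

Working notes on the series. Within the data shown here, only two compounds have measured values so far. In a functional assay on DU-145 cells (Homo sapiens) for inhibition, read by trypan blue exclusion, with a stated time of 96 h (a higher number here means a weaker inhibitor of growth, a lower number a stronger inhibitor of growth), compound 1 (`Cc1ccc(S/C(=C/c2sccc2C)C(=O)c2ccc(Br)cc2)cc1`) gives 50000 nM, the higher of the two numbers. Compound 2 (`O=C(/C(=C\c1ccc(O)c([N+](=O)[O-])c1)SCc1ccc(Cl)cc1)c1ccc(Cl)cc1`) gives 10000 nM, a lower number beyond the scatter, which makes compound 1 the weaker growth inhibitor of this pair. Among the measured compounds shown here, the two compounds are not linked by a change in one place, so no single-change step is available.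

Compound 3 (`CSc1ccc(/C=C(/Sc2ccc(C)cc2)C(=O)c2ccc(Br)cc2)cc1`) has 4-(methylsulfanyl)phenyl in place of 3-methylthiophen-2-yl on a double-bonded chain carbon bound to a double-bonded chain carbon. For the measured compounds named here, no measured pair shows this exchange, so the expectation rests on little. Compound 1, at 50000 nM, is the top of the measured range, and compound 2, at 10000 nM, is the only lower reference. The expected change is small, toward a lower number and not clearly beyond the scatter: a 1.8-fold lower number from compound 1 to compound 3 (0.25 log units; within the scatter). In this assay the estimate for compound 3 is 28000 nM, with an expected range of 8000 nM to 80000 nM.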

Compound 3, concentration for 50% growth inhibition: 50000 nM
Estimate against measurement, compound 3: 1.8-fold (0.25 log units) below; the measured number falls inside the stated range.
By their numbers in this assay, from the lowest: compound 2; then compounds 1 and 3 (each within the scatter of the next).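

In this assay, among these compounds, the exchange of 3-methylthiophen-2-yl for 4-(methylsulfanyl)phenyl on a double-bonded chain carbon bound to a double-bonded chain carbon gives no change at the digits printed from compound 1 to compound 3 (within the scatter) and is the first single-change step. Among the compounds shown here, at this position, therefore, a five-membered aromatic ring with 1 hetero atom and a six-membered aromatic ring of carbon only give the same reading on this shared core, so the first look at this place shows no separation between the two groups. No available evidence bears on this result.

Open, as far as these compounds go, is whether a group of another kind at this place, such as a primary amine, a carboxylic acid or a longer alkyl chain, would give a reading that separates from these two, and whether the same exchange would read alike on the core of compound 2. Compound 2 remains joined to neither of the other compounds by a change in one place, so its lower number cannot yet be assigned to any single part of its structure.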